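Chloro for acetyl on a shared thiazole amide core

The source may report more compounds than this note shows. Statements on the series, on what has been measured and on what is new or still open speak of the compounds shown alone.

Measured compounds:
compound 1 `COc1ccccc1C(=O)Nc1nc(-c2ccccn2)cs1`, 43500 nM
compound 2 `CC(=O)c1cccc(C(=O)Nc2nc(-c3ccccn3)cs2)c1`, 1500 nM

Of the compounds shown here, two have been tested in an ADME assay on Vero cells (Chlorocebus sabaeus) for cytotoxicity, read by MTT assay, with a stated time of 72 h; on this read-out higher numbers stand for an effect only at larger amounts of compound and lower numbers for an effect already at smaller amounts. Compound 1 `COc1ccccc1C(=O)Nc1nc(-c2ccccn2)cs1` gives 43500 nM. Compound 2 `CC(=O)c1cccc(C(=O)Nc2nc(-c3ccccn3)cs2)c1` gives 1500 nM, which is the lowest of the two numbers; the gap between compound 2 and compound 1 lies beyond the usual scatter of the measurement. For the measured compounds named here, the two compounds differ in more than one place, so no single step between them can be read from their structures.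

Compound 3 `O=C(Nc1nc(-c2ccccn2)cs1)c1cccc(Cl)c1` has not yet been measured in this assay. Its relation to compound 2 is a single change: chloro in place of acetyl on an aromatic carbon. Going by the values given here, nothing among the measured compounds shows what a chloro in place of an acetyl on this aromatic carbon does to the read-out, so the expectation rests on compound 2 alone. The author expects compound 3 to give a somewhat higher number than compound 2, a step of a 2.7-fold higher number from compound 2 to compound 3 (0.43 log units; beyond the scatter), but one that may still fall within the scatter. The estimate for compound 3 in this assay is 4000 nM, with a range from 1200 nM to 20000 nM.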

Compound 3, half-maximal effective concentration: 7000 nM
The estimate for compound 3 lay 1.8-fold (0.24 log units) below the measured number, and the stated range covers the measured number.
By their numbers in this assay, from the lowest: compound 2; then compound 3; then compound 1.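

In this assay, for the compounds shown here, the replacement of acetyl by chloro on this aromatic carbon, meta to a large group, gives the first direct reading of what this position does: a 4.7-fold higher number from compound 2 to compound 3 (0.67 log units; beyond the scatter), a modest step that lies beyond the scatter. The earlier compounds shown here differed in more than one place and could not show this, whereas this pair shows that the read-out responds to a change at this one carbon while the rest of the structure stays the same. The change takes away three heavy atoms, a double bond outside aromatic rings and a hydrogen-bond acceptor and puts a single chlorine in their place, so these differences all travel together in this one step and the pair cannot separate them. Nothing measured alongside the step ties it to any property of either group.

Going by these compounds alone, it remains open how an amine or a carboxylic acid on this same carbon would read, since acetyl and chloro are the only two groups seen there. As far as these compounds go, it is also open whether a longer chain at this place would move the number further, and whether the chloro for acetyl step would hold on another core.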